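Carbamate series: hydrogen in place of an aromatic methyl

The source may hold more compounds than are shown below. What is called first, only, known or untested is meant among the compounds shown, and "the series" means these compounds.

In a functional assay on MDA-MB-231 cells (Homo sapiens) for antiproliferative activity, read by MTT assay, with a stated time of 96 h (on this read-out higher numbers stand for weaker inhibition and lower numbers for stronger inhibition), compound 1 (`CC(C)=CCC/C(C)=C/CC/C(C)=C/CC[C@]1(C)CCc2cc(OC(=O)NS(=O)(=O)c3ccc(C)cc3)c(C)c(C)c2O1`) gives > 10000 nM, which is a limit and not a number. Going by the values given here, compound 2 (`CC(C)=CCC/C(C)=C/CC/C(C)=C/CC[C@]1(C)CCc2c(C)c(OC(=O)NCc3ccccc3)c(C)c(C)c2O1`) gives 7200 nM, the only actual number so far in this short series. Compound 3 (`CC(C)=CCC/C(C)=C/CC/C(C)=C/CC[C@]1(C)CCc2cc(OC(=O)NCc3ccccc3)c(C)c(C)c2O1`) differs from compound 2 by hydrogen in place of methyl on an aromatic carbon. Among the compounds with values here, no measured pair covers this change, so only a modest effect is expected, and it may stay within the scatter. The expected shift, a 1.3-fold lower number from compound 2 to compound 3 (0.12 log units; within the scatter), leans slightly towards stronger inhibition. For compound 3 the estimated value is 5500 nM, with an expected range of 2000 nM to 13000 nM.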

Compound 3, half-maximal inhibitory concentration: > 10000 nM
Compound 3 gave a limit, no number; the forecaster's own chance of this, stated with the estimate: 15%; at least 1.8-fold (0.25 log units) between middle value and limit.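

In this assay, hydrogen in place of the methyl ortho to a (benzylcarbamoyl)oxy group gives an at least 1.3-fold higher number from compound 2 to compound 3 (0.14 log units; that floor lies within the scatter). Only this floor is known, so the methyl at this position is not yet shown to matter beyond the scatter. The value of compound 3 is a limit and not a number: the limit of > 10000 nM in this assay, at which 2 of the 3 values shown sit.

The two limits leave the change from (4-methylphenyl)sulfonyl to benzyl on the amide-type nitrogen unreadable. Also open, as far as these compounds go, are the true size of the methyl-to-hydrogen step and whether a methoxy or chlorine on this aromatic carbon would give a number.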